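Epimer at the fluorinated carbon of an acid agonist

The source may report more compounds than this note shows. Statements on the series, on what has been measured and on what is new or still open speak of the compounds shown alone.

Compound 1 `COc1ccc(F)c([C@H]2CC[C@H](COc3cccc([C@@H](CC(=O)O)C4CC4)c3)CC2)c1` carries a cyclopropyl-bearing propanoic acid and serves as the reference point of the series. In a functional assay on cells for agonist activity at Free fatty acid receptor 1 (Homo sapiens), read by HTRF and inositol phosphate accumulation, with a stated time of 90 min (a lower number here means that less compound is needed, a higher number that more compound is needed for the effect), compound 1 gives 199 nM. On these data alone, compound 2 `COc1ccc(F)c([C@H]2CC[C@H](COc3cccc([C@H](C4CC4)[C@H](F)C(=O)O)c3)CC2)c1` bears a fluorine on the carbon next to the carboxylic acid; in this assay compound 2 gives "not determined" (no result reported), so its standing on the numbers is unknown and nothing can be placed beside the value of compound 1 for it. Compound 3 `COc1ccc(F)c([C@H]2CC[C@H](COc3cccc([C@H](C4CC4)[C@@H](F)C(=O)O)c3)CC2)c1` is its diastereomer: the two compounds have the same atoms and bonds and differ only in configuration as drawn: 1 of 4 stereo elements differ; a stereocentre at a saturated chain carbon is drawn S in compound 2 and R in compound 3. Since neither compound 2 nor any pair of measured compounds supplies a step, no measured size of change can be read for this inversion. For such a swap of configuration at the carbon bearing the fluorine the expected outcome in this assay is uncertain in direction, and a difference beyond the scatter between the two epimers would not be surprising, though none is documented here. Taking compound 1 with its 199 nM as the only anchor, compound 3 is expected to give about 300 nM, with a plausible range from 50 nM to 3000 nM.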

Compound 3, half-maximal effective concentration: 20 nM
Compound 3: middle estimate off by 15-fold (1.18 log units), on the high side; measured number outside the range, below it.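

The saturated chain carbon bound to a carbonyl carbon accepts fluoro in place of hydrogen without loss in this assay: with the configuration drawn R at that carbon, as in compound 3, the change gives a 10-fold lower number from compound 1 to compound 3 (1.00 log units; beyond the scatter). Going by these compounds alone, this is the first measured step, and it shows that exchanging this one hydrogen can lower the concentration needed, by a margin beyond the scatter, rather than raise it. Compound 2 has no number, so no step to or from it can be read, and what is known of this pair is structural only: the fact that compounds 2 and 3 differ only in the configuration as drawn

The compounds shown therefore leave open how much the configuration at the fluorinated carbon matters, since the result for compound 3 stands without a measured epimer beside it. Within the data shown here, they also leave open whether a hydroxyl group, a methyl group or a second fluorine on that same carbon would move the number in the same direction as the single fluoro group does.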